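Methyl to ethyl at the ester of compound 1

A few compounds are considered here, and "the series" means these few. Any claim that something is new, unique, unknown or untested is made for them only; others in the source may bear on it.

Measured: compound 1 `COC(=O)[C@@H](N)CSNC(=O)[C@@H](CCC(F)(F)F)N(Cc1ccc(-c2ncon2)cc1F)S(=O)(=O)c1ccc(Cl)cc1` with 185 h; compound 2 `N#CCCSNC(=O)[C@@H](CCC(F)(F)F)N(Cc1ccc(-c2ncon2)cc1F)S(=O)(=O)c1ccc(Cl)cc1` with > 500 h.

Within the data shown here, compound 1 holds the only plain number in a physicochemical assay for pharmacokinetics, at pH 4, tested at 100 ug/mL (on this read-out lower numbers stand for a shorter-lived compound and higher numbers for a longer-lived compound), namely 185 h. For compound 2 this assay reports only a limit, > 500 h, which is the limit of > 500 h in this assay, at which 1 of the 2 values shown sits. Among the measured compounds shown here, the single measured step, an at least 2.7-fold higher number from compound 1 to compound 2 (0.43 log units; beyond the scatter), changes the chain bound to the sulfur and not the ester. Compound 3 `CCOC(=O)[C@@H](N)CSNC(=O)[C@@H](CCC(F)(F)F)N(Cc1ccc(-c2ncon2)cc1F)S(=O)(=O)c1ccc(Cl)cc1` differs from compound 1 by methyl in place of hydrogen on a saturated chain carbon bound to an oxygen next to a carbonyl group. For the measured compounds named here, no measured step touches that place, so the expectation for compound 3 is no step beyond the scatter, a 1.1-fold higher number from compound 1 to compound 3 (0.06 log units; within the scatter). Compound 3 is therefore estimated at 210 h, between 100 h and 450 h.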

Compound 3, half-life: 258 h
Compound 3: middle estimate off by 1.2-fold (0.09 log units), on the low side; measured number inside the range.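

In this assay, going from methoxycarbonyl to ethoxycarbonyl gives a 1.4-fold higher number from compound 1 to compound 3 (0.14 log units; within the scatter), so adding this methyl on the saturated chain carbon bound to an oxygen next to a carbonyl group produces no step beyond the scatter. Set against the cyanomethyl chain, the amino(ethoxycarbonyl)methyl chain gives an at least 1.9-fold lower number from compound 2 to compound 3 (0.28 log units; that floor lies within the scatter), so this gap is not shown to exceed the scatter. Compound 2 carries a limit, not a number: the limit of > 500 h in this assay, at which 1 of the 3 values shown sits.

The compounds shown leave open how a longer chain or a branched isopropyl group at the ester would read. They also leave open how the carboxylic acid would read.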